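Anilide series at alpha4/beta2: piperidinyl for 3-fluorophenylamino

The source may report more compounds than this note shows. Statements on the series, on what has been measured and on what is new or still open speak of the compounds shown alone.

Compound 1 `CCCCCCNc1cccc(NC(=O)c2ccc(OCCC)cc2)n1` gives only a limit, > 100000 nM, in an in vitro assay on HEK-tsA201 cells for antagonist activity at Neuronal acetylcholine receptor; alpha4/beta2 (Homo sapiens), read by fluorescence and calcium flux; on this read-out higher numbers stand for weaker inhibition and lower numbers for stronger inhibition. Compound 2 `CCCOc1ccc(C(=O)Nc2cccc(Nc3cccc(F)c3)n2)cc1` likewise gives only a limit, > 100000 nM, in this assay.

Compound 2 therefore has no number in this assay, only the limit; it stands where every value here stands, described by the limit of > 100000 nM in this assay, at which 2 of the 2 values shown sit. Among the compounds with values here, the one measured step, a step that the two limits leave unreadable from compound 1 to compound 2, cannot be sized, since both of its ends are limits; it says nothing about the direction of a change at this nitrogen.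

Compound 3 `CCCOc1ccc(C(=O)Nc2cccc(N3CCCCC3)n2)cc1` differs from compound 2 by piperidin-1-yl in place of (3-fluorophenyl)amino on an aromatic carbon. Within the data shown here, no measured step bears on this change, and the only measured step is itself unreadable. With both neighbours at the limit, compound 3 is expected to give a limit again, with a step that the limit leaves unreadable from compound 2 to compound 3 meaning no shift beyond the scatter. The estimate for compound 3 in this assay is 150000 nM, with a range from 30000 nM to 1000000 nM.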

Compound 3, half-maximal inhibitory concentration: > 100000 nM
Compound 3: a limit, no number; the forecaster's own chance of this, stated with the estimate: 85%; the middle value lies beyond the limit too.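

In this assay compound 3 gives > 100000 nM, a limit and not a number, so its steps from compound 1 and compound 2 cannot be read. The compounds shown leave open whether any group at this place on the shared core gives a measurable inhibition.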